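The compounds below may be only part of what the source reports. "The series", "measured", "known", "first", "only" and "open" are said of these compounds alone.

Working notes on the series. The shared core is seen in compound 1 `CCN(Cc1c(C(F)(F)F)nc2n(-c3c(C)cc(C)cc3C)c(Cl)cn12)CC1CCC1`, which in an assay on cells for displacement of a labelled ligand from corticotropin-releasing factor receptor 1 (Homo sapiens), with a stated time of 100 min (a higher number here means a weaker inhibitor, a lower number a stronger inhibitor), gives 16 nM. Compound 2 `Cc1cc(C)c(-n2c(Cl)cn3c(CN(CCC4CC4)CCC(F)(F)F)c(C(F)(F)F)nc23)c(C)c1` gives in this assay 110 nM, and compound 3 `Cc1cc(C)c(-n2c(Cl)cn3c(CN(CCC(F)(F)F)Cc4ccccc4)c(C(F)(F)F)nc23)c(C)c1` gives in this assay 43 nM. Compound 3 thus stands second highest of the three numbers, with compound 2 nearest and compound 1 furthest, both gaps beyond the scatter. Within the data shown here, the one step that runs between two of these, a 2.6-fold lower number from compound 2 to compound 3 (0.41 log units; beyond the scatter), was modest though beyond the scatter.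

Compound 4 `Cc1cc(C)c(-n2c(Cl)cn3c(CN(CCC(F)(F)F)Cc4ccc(Cl)cc4)c(C(F)(F)F)nc23)c(C)c1` differs from compound 3 by chloro in place of hydrogen on an aromatic carbon. Among the measured compounds shown here, no measured pair shows what a chloro in place of hydrogen on the benzyl does; the step of a 2.6-fold lower number from compound 2 to compound 3 (0.41 log units; beyond the scatter) concerns the exchange of the whole group on the amine and so bears only loosely on compound 4. The expected step of a 1.2-fold lower number from compound 3 to compound 4 (0.09 log units; within the scatter) is therefore none beyond the scatter, with the range kept wide for want of a precedent. Compound 4 is estimated to give 35 nM in this assay, within a range from 12 nM to 110 nM.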

Compound 4, inhibition constant: 12 nM
For compound 4 the middle estimate is 2.9-fold (0.46 log units) above the measured one; the measured number falls inside the stated range.
By their numbers in this assay, from the lowest: compounds 4 and 1 (each within the scatter of the next); then compound 3; then compound 2.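

In this assay the series gains its first reading of a substituent on the benzyl ring: chloro in place of hydrogen, para to a large group, gives a 3.6-fold lower number from compound 3 to compound 4 (0.55 log units; beyond the scatter) and so the ring carbon at this place is not indifferent to change. Exchanging cyclopropylmethyl for 4-chlorophenyl on the amine side chain gives a 9.2-fold lower number from compound 2 to compound 4 (0.96 log units; beyond the scatter), which shows that the single added chlorine extends the change already seen with the unsubstituted phenyl in a 2.6-fold lower number from compound 2 to compound 3 (0.41 log units; beyond the scatter). No supporting data bear on why the chloro has this effect.

From the compounds shown here alone, how a fluoro, a methoxy or a nitrile would compare with chloro on this carbon remains open, as does chloro on another carbon of the ring. Also open, going by these compounds, is whether the step from benzyl to 4-chlorobenzyl would hold with an ethyl on the amine in place of the trifluoropropyl chain.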